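Chloro for Fluoro, Tested on a Second Core

This account rests on a few compounds, and the source may have more. Where it says the series, first, only, none or still open, it means among the compounds named here.

Compound 1 `COc1ccc2nc(NC(=O)c3cn(-c4ccccc4)nc3-c3ccc(F)cc3)sc2c1` and compound 2 `COc1ccc2nc(NC(=O)c3cn(-c4ccccc4)nc3-c3ccc(Cl)cc3)sc2c1` share one core. In a functional assay on HT-29 cells (Homo sapiens) for cytotoxicity, read by MTT assay, with a stated time of 72 h (on this read-out lower numbers stand for stronger inhibition and higher numbers for weaker inhibition), compound 1 gives 33200 nM, while compound 2 gives 18600 nM. The change between them, (chloro in place of fluoro on an aromatic carbon), produced a 1.8-fold lower number from compound 1 to compound 2 (0.25 log units; within the scatter).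

Compound 3 `COc1ccc(-c2nn(-c3ccccc3)cc2C(=O)Nc2nc3ccc(F)cc3s2)cc1` has the same atoms as compound 1 joined differently; the difference between the two cores is not broken down here. In this assay compound 3 gives 5560 nM.

Compound 4 `COc1ccc(-c2nn(-c3ccccc3)cc2C(=O)Nc2nc3ccc(Cl)cc3s2)cc1` carries the change (chloro in place of fluoro on an aromatic carbon). This is the same kind of change as in the first pair, but the place differs: here the aromatic carbon is part of a fused or bridged system of two rings, meta to a fused ring and para to a fused ring, rather than para to a large group.

The step from compound 3 to compound 4 is expected to be a 1.4-fold lower number from compound 3 to compound 4 (0.14 log units; within the scatter), resting on a 1.8-fold lower number from compound 1 to compound 2 (0.25 log units; within the scatter). Compound 4 is therefore estimated at 4000 nM, expected between 1500 nM and 12000 nM.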

Compound 4, half-maximal inhibitory concentration: 6570 nM
Beside the measured number, compound 4's estimate is 1.6-fold (0.22 log units) below it; measured number inside the range.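

On the second core, chloro in place of fluoro gave a 1.2-fold higher number from compound 3 to compound 4 (0.07 log units; within the scatter) in this assay. Going by these compounds alone, the two steps for this change do not separate from each other: the same change on two cores in this assay, a 1.8-fold lower number (0.25 log units; within the scatter) from compound 1 to compound 2 and a 1.2-fold higher number (0.07 log units; within the scatter) from compound 3 to compound 4, 2.1-fold (0.32 log units) apart, within the scatter of two such steps So on these two cores the change stays within the scatter each time, but that does not show that it has the same effect on both, since the steps are small, there are only two pairs, and the change sits at a different place in each.

The compounds shown leave open how a bromo, a methyl or an amine at either place would read in this assay, and whether any such group would give a step beyond the scatter.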